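Piperazine nitrogen substituent and alpha-1 affinity in the series

The source may hold more compounds than are shown below. What is called first, only, known or untested is meant among the compounds shown, and "the series" means these compounds.

Of the compounds shown here, three of one series have been measured so far. Compound 1 `COc1ccccc1N1CCN(CCCCn2nc(-c3ccc(C)cc3)c3ccccc3c2=O)CC1` gives 2.6 nM in an assay on Cerebral cortex for displacement of a labelled ligand from Adrenergic receptor alpha-1 (Rattus norvegicus); on this read-out higher numbers stand for weaker inhibition and lower numbers for stronger inhibition. Compound 2 `Cc1ccc(-c2nn(CCCCN3CCN(c4ccccc4OC(C)C)CC3)c(=O)c3ccccc23)cc1` gives 1.07 nM, and the step of a 2.4-fold lower number from compound 1 to compound 2 (0.39 log units; beyond the scatter) is modest. Compound 3 `Cc1ccc(-c2nn(CCCCN3CCN(CC4COc5ccccc5O4)CC3)c(=O)c3ccccc23)cc1` gives 180 nM, the highest of the three numbers; the steps of a 69-fold higher number from compound 1 to compound 3 (1.84 log units; beyond the scatter) and a 170-fold higher number from compound 2 to compound 3 (2.23 log units; beyond the scatter) are both large, so compound 3 stands well apart from the other two.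

Compound 4 `Cc1ccc(-c2nn(CCCCN3CCN(c4cccc(Cl)c4)CC3)c(=O)c3ccccc23)cc1` is not yet measured. Relative to compound 3 the change is 3-chlorophenyl in place of (2,3-dihydro-1,4-benzodioxin-2-yl)methyl on an amine nitrogen in a ring. For the measured compounds named here, two measured steps bear on this position: both a 69-fold higher number from compound 1 to compound 3 (1.84 log units; beyond the scatter) and a 170-fold higher number from compound 2 to compound 3 (2.23 log units; beyond the scatter) show that exchanging an aryl group on the ring nitrogen for the (2,3-dihydro-1,4-benzodioxin-2-yl)methyl group raised the number by a large amount. Going by the values given here, compound 4 moves back to an aryl group on that nitrogen, though a 3-chlorophenyl rather than an alkoxyphenyl, and no measured step covers that particular aryl. A large step downward is therefore expected, a 23-fold lower number from compound 3 to compound 4 (1.35 log units; beyond the scatter), with the number for compound 4 expected near that of compound 1 or somewhat higher. The estimate for compound 4 is 8 nM, in the range 1.5 nM to 45 nM.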

Compound 4, inhibition constant: 12.4 nM
Beside the measured number, compound 4's estimate is 1.6-fold (0.19 log units) below it; the range from low to high includes it.
By their numbers in this assay, from the lowest: compound 2; then compound 1; then compound 4; then compound 3.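

In this assay the exchange of (2,3-dihydro-1,4-benzodioxin-2-yl)methyl for 3-chlorophenyl on the ring nitrogen gives a 15-fold lower number from compound 3 to compound 4 (1.16 log units; beyond the scatter) and so recovers much of the difference between that group and the alkoxyphenyl groups, with no alkoxy group on the aryl ring. The recovery is incomplete: 3-chlorophenyl in place of 2-methoxyphenyl gives a 4.8-fold higher number from compound 1 to compound 4 (0.68 log units; beyond the scatter) and in place of 2-isopropoxyphenyl gives a 12-fold higher number from compound 2 to compound 4 (1.06 log units; beyond the scatter), so within these four compounds the identity of the aryl group also affects the number. No measured data accompany these compounds that could account for this order.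

Compound 4 differs from compound 1 in both the substituent on the aryl ring and its place, so the contribution of each remains unresolved; 2-chlorophenyl, 3-methoxyphenyl and unsubstituted phenyl would separate them. As far as these compounds go, whether the large gap to compound 3 follows from the aryl group sitting directly on the ring nitrogen or from the benzodioxin ring system is also open, and a benzyl group on that nitrogen would test it.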